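The source may hold more compounds than are shown below. What is called first, only, known or untested is meant among the compounds shown, and "the series" means these compounds.

Of the compounds shown here, three share a common heart and have been measured in an assay on isolated protein for inhibition of long-chain fatty acid transport protein 1 (Homo sapiens); on this read-out higher numbers stand for weaker inhibition and lower numbers for stronger inhibition. Compound 1, `CCn1c(CNc2ccccc2)nnc1SCc1nc2cc(OC(F)(F)F)ccc2o1`, gives 100 nM. Compound 2, `CCC(=O)c1ccc2nc(CSc3nnc(CNc4ccccc4)n3CC)oc2c1`, gives 900 nM, and compound 3, `CCOC(=O)c1ccc(NC(=O)CSc2nnc(CSCc3ccccc3)n2CC)cc1`, gives 7600 nM. Compound 1 therefore stands lowest of the three, and both gaps to it lie beyond the usual scatter, so it is the strongest inhibitor among the measured set.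

Compound 4, `CCn1c(CNc2ccccc2)nnc1SCc1nc2cc(F)ccc2o1`, has not yet been measured. It differs from compound 1 in a single place: fluoro in place of trifluoromethoxy on an aromatic carbon. Going by the values given here, no measured pair shows this particular change, so there is no direct precedent for its size. A small group takes the place of a larger one on the same aromatic carbon, and a modest move toward weaker inhibition seems the more likely outcome, though a step that stays within the scatter cannot be excluded.

Compound 4 is expected to give about 250 nM, within a range from 80 nM to 800 nM. This corresponds to an expected 2.5-fold higher number from compound 1 to compound 4 (0.40 log units; beyond the scatter).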

Compound 4, half-maximal inhibitory concentration: > 1000 nM
Compound 4 gave a limit, no number (the forecaster's own chance of this, stated with the estimate: 3%); middle value at least 4.0-fold (0.60 log units) away from the limit.
By their numbers in this assay, from the lowest: compound 1; then compound 2; then compound 3.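

In this assay compound 4 gives > 1000 nM, which is a limit of the assay and not a number. Even so, this is the first comparison in the set where only one place changes, and fluoro in place of trifluoromethoxy on this aromatic carbon gives an at least 10-fold higher number from compound 1 to compound 4 (1.00 log units; beyond the scatter), so inhibition clearly depends on what this carbon carries. This step is a floor rather than an exact size, and it rests on a single pair of compounds: the limit of > 1000 nM in this assay, at which 1 of the 4 values shown sits.

From the compounds shown here alone, only these two groups appear on this carbon, so it remains open whether a trifluoromethyl group, a methoxy group or a chlorine atom would keep inhibition close to that of compound 1. Going by these compounds, it also remains open how a plain hydrogen at this place would compare with either group.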